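Trifluoromethyl for chloro on a chloropyridinyl ether

The source may hold more compounds than are shown below. What is called first, only, known or untested is meant among the compounds shown, and "the series" means these compounds.

Compound 1, `Cn1c(CN2C[C@@H]3C(COc4ccc(Cl)cc4)[C@@H]3C2)nc2ccccc21`, gives 6.6 mL/min/kg in an in vitro ADME assay on microsomes from liver (Homo sapiens) for metabolic stability, tested at 1 uM; on this read-out higher numbers stand for fast clearance and lower numbers for slow clearance.
Compound 2, `Cn1c(CN2C[C@@H]3C(COc4ccc(C(F)(F)F)cc4)[C@@H]3C2)nc2ccccc21`, gives < 5.3 mL/min/kg in this assay, a value that is a limit of the assay and not a number.
Compound 3, `Cn1c(CN2C[C@@H]3C(COc4ccc(Cl)cn4)[C@@H]3C2)nc2ccccc21`, gives 12.3 mL/min/kg in this assay.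

Compound 3 differs from compound 1 by 5-chloropyridin-2-yl in place of 4-chlorophenyl on an oxygen on a saturated carbon, and in this assay this gives a 1.9-fold higher number from compound 1 to compound 3 (0.27 log units; within the scatter). Compound 2 differs from compound 1 by trifluoromethyl in place of chloro on an aromatic carbon, and this assay shows an at least 1.2-fold lower number from compound 1 to compound 2 (0.09 log units; that floor lies within the scatter); the floor of that step comes from the limit of < 5.3 mL/min/kg in this assay, at which 1 of the 3 values shown sits.

Compound 4, `Cn1c(CN2C[C@@H]3C(COc4ccc(C(F)(F)F)cn4)[C@@H]3C2)nc2ccccc21`, has not been measured. It differs from compound 3 by trifluoromethyl in place of chloro on an aromatic carbon. This is the same kind of change as that from compound 1 to compound 2, but not the same: in compound 4 the trifluoromethyl sits on a six-membered aromatic ring with 1 nitrogen, two atoms from the ring nitrogen, whereas in compound 2 it sits on a six-membered aromatic ring of carbon only. Beside an at least 1.2-fold lower number from compound 1 to compound 2 (0.09 log units; that floor lies within the scatter), the step expected in this assay is a 1.4-fold lower number from compound 3 to compound 4 (0.16 log units; within the scatter), resting on compound 3 at 12.3 mL/min/kg as the starting point and on the measured step from compound 1 to compound 2 as the only guide. Compound 4 is thus estimated at 8.5 mL/min/kg in this assay, with the plausible range expected to run from 4.5 mL/min/kg to 16 mL/min/kg.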

Compound 4, clearance: < 5.3 mL/min/kg
Compound 4 ended at the assay's limit; the forecaster's own chance of this, stated with the estimate: 25%; middle value at least 1.6-fold (0.20 log units) from the limit.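

Trifluoromethyl in place of chloro on the nitrogen-containing aromatic ring gives an at least 2.3-fold lower number from compound 3 to compound 4 (0.36 log units; beyond the scatter) in this assay, so on the core of compound 3 this change reads as a real drop in the number and not as scatter. Set beside the step on the core of compound 1, whose floor stays within the scatter, the result shows that the change can be carried to the second core without the number rising, but it does not show that the two cores respond alike or differently: the same change on two cores in this assay, an at least 1.2-fold lower number (0.09 log units; that floor lies within the scatter) from compound 1 to compound 2 and an at least 2.3-fold lower number (0.36 log units; beyond the scatter) from compound 3 to compound 4; the limit leaves it open whether they differ Compound 2 and compound 4 each stand at a limit of the assay and not at a number, so the true size of neither step is known and no ranking of the two compounds can be drawn: the limit of < 5.3 mL/min/kg in this assay, at which 2 of the 4 values shown sit.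

The compounds shown leave open whether a nitrile, a methyl group or a methoxy group in the place of the chloro would read in this assay as trifluoromethyl does. They also leave open whether an amine or a carboxylic acid on this ring would fit the same picture, and whether the step would carry to any core beyond these two.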